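The compounds below may be only part of what the source reports. "The series", "measured", "known", "first", "only" and "open" are said of these compounds alone.

Compound 1 `CCCCCCCCCCCCNC(=O)[C@@H](NC(=O)c1cccs1)[C@@H](C)O` and compound 2 `CCCCCCCCCCCCNC(=O)[C@@H](NS(=O)(=O)c1ccc(C)cc1)[C@@H](C)O` share a core and differ only in the group on the amine nitrogen. In a functional assay on MCF7 cells (Homo sapiens) for cytotoxicity, read by MTT assay, with a stated time of 48 h (on this read-out higher numbers stand for weaker inhibition and lower numbers for stronger inhibition), compound 1 gives 30400 nM, and compound 2 gives 31100 nM; the step of a 1.0-fold higher number from compound 1 to compound 2 (0.01 log units; within the scatter) is within the scatter. Compound 3 `CCCCCCCCCCCCCCNC(=O)[C@@H](NC(=O)c1cccs1)[C@@H](C)O` differs from compound 1 by ethyl in place of hydrogen on a saturated chain carbon, ten or more bonds along the chain from an amide-type nitrogen. Within the data shown here, no measured step touches that chain, so no step gives a lead for this change. Compound 3 is therefore expected to show a step of a 1.0-fold lower number from compound 1 to compound 3 (0.01 log units; within the scatter), within the scatter, with an estimated value of 30000 nM in this assay, between 12000 nM and 80000 nM.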

Compound 3, half-maximal inhibitory concentration: 36100 nM
Compound 3: the middle estimate sits 1.2-fold (0.08 log units) below what was measured, and the stated range covers the measured number.
By their numbers in this assay, from the lowest: compounds 1, 2 and 3 (each within the scatter of the next).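

The chain now has a measured step of its own: in this assay, ethyl in place of hydrogen on a saturated chain carbon, ten or more bonds along the chain from an amide-type nitrogen, gives a 1.2-fold higher number from compound 1 to compound 3 (0.07 log units; within the scatter). This lengthening therefore leaves the number indistinguishable from that of compound 1. No supporting measurement bears on this result.

As far as these compounds go, whether a much shorter chain, such as hexyl, or a chain ending in an amine or a carboxylic acid would shift the number stays open. So does whether the same lengthening behaves alike with the (4-methylphenyl)sulfonyl group of compound 2.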